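This account rests on a few compounds, and the source may have more. Where it says the series, first, only, none or still open, it means among the compounds named here.

Working notes on the sulfonate ester series. In a functional assay on HT-1080 cells (Homo sapiens) for antiproliferative activity, read by sulforhodamine B assay, with a stated time of 48 h (a higher number here means a weaker inhibitor, a lower number a stronger inhibitor), compound 3 `CC(C)c1ccccc1OS(=O)(=O)c1ccc(NC(=O)CCCCl)cc1` gives 3800 nM, the low end of the three numbers recorded so far; compound 1 `CC(C)C(=O)Nc1ccc(S(=O)(=O)Oc2ccccc2C(C)C)cc1` gives 4900 nM and compound 2 `CC(C)c1ccccc1OS(=O)(=O)c1ccc(NC(=O)C(C)(C)C)cc1` gives 11000 nM. The steps among them are small: a 1.3-fold lower number from compound 1 to compound 3 (0.11 log units; within the scatter), a 2.9-fold lower number from compound 2 to compound 3 (0.46 log units; beyond the scatter), and a 2.2-fold higher number from compound 1 to compound 2 (0.35 log units; beyond the scatter).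

Compound 4 `CCCCCNC(=O)Nc1ccc(S(=O)(=O)Oc2ccccc2C(C)C)cc1` differs from compound 3 in one place: pentylamino in place of 3-chloropropyl on a carbonyl carbon. Among the measured compounds shown here, no measured step swaps the carbon chain on the carbonyl for a pentylamino group, so the bearing of the three steps is indirect; they show only that changing the group on this carbonyl moves this assay by modest amounts. The expectation for compound 4 is therefore a step near the scatter, a 1.4-fold higher number from compound 3 to compound 4 (0.16 log units; within the scatter), giving an estimated 5500 nM (range 1800 nM to 17000 nM).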

Compound 4, half-maximal inhibitory concentration: 4700 nM
Estimate against measurement, compound 4: 1.2-fold (0.07 log units) above, and the stated range covers the measured number.
By their numbers in this assay, from the lowest: compounds 3, 4 and 1 (each within the scatter of the next); then compound 2.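

On this carbonyl carbon, pentylamino, which brings a nitrogen onto the carbonyl, fits the level of the carbon-chain groups in this assay: a 1.2-fold higher number from compound 3 to compound 4 (0.09 log units; within the scatter) and a 1.0-fold lower number from compound 1 to compound 4 (0.02 log units; within the scatter) both stay within the scatter. Only tert-butyl stands apart, with a 2.3-fold lower number from compound 2 to compound 4 (0.37 log units; beyond the scatter) beyond the scatter, so the gap seen earlier for that group also holds against a nitrogen-linked chain. Nothing on hand explains these steps.

Open, going by these compounds, is whether a shorter amine such as methylamino, anilino, or a chain ending in a carboxylic acid in place of pentylamino would stay at this level.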